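The source may hold more compounds than are shown below. What is called first, only, known or untested is meant among the compounds shown, and "the series" means these compounds.

Among the three measured compounds, compound 2 `Cc1nn(-c2nc(-c3ccc(Cl)c(Cl)c3)c(SC(C)C)s2)c(C(=O)O)c1-c1cncnc1` stands highest in a functional assay on BJAB cells (Homo sapiens) for antiproliferative activity, with a stated time of 4 days (on this read-out higher numbers stand for an effect only at larger amounts of compound and lower numbers for an effect already at smaller amounts), where compound 2 gives 22000 nM. Compound 3 `Cc1nn(-c2nc(-c3ccc(Cl)c(Cl)c3)c(SC(C)C)s2)c(C(=O)O)c1-c1ccccc1Cl` gives 13100 nM in this assay, and compound 1 `Cc1ccccc1-c1c(C)nn(-c2nc(-c3ccc(Cl)c(Cl)c3)c(SC(C)C)s2)c1C(=O)O` gives 5500 nM. The step of a 4.0-fold higher number from compound 1 to compound 2 (0.60 log units; beyond the scatter) lies beyond the scatter, whereas the step of a 1.7-fold lower number from compound 2 to compound 3 (0.23 log units; within the scatter) stays within it. Compound 4 `Cc1nn(-c2nc(-c3ccc(Cl)c(Cl)c3)c(SC(C)C)s2)c(C(=O)O)c1-c1cccc(Cl)c1` differs from compound 2 by 3-chlorophenyl in place of pyrimidin-5-yl on an aromatic carbon. The closest measured parallel is the exchange of pyrimidin-5-yl for a chlorophenyl ring, a 1.7-fold lower number from compound 2 to compound 3 (0.23 log units; within the scatter), which gave a lower number but not beyond the scatter; the step of a 4.0-fold higher number from compound 1 to compound 2 (0.60 log units; beyond the scatter), read in reverse, shows that trading pyrimidin-5-yl for a phenyl ring carrying a small substituent can lower the number modestly. Taken together, a lower number for compound 4 is expected, and the step is estimated at a 2.4-fold lower number from compound 2 to compound 4 (0.39 log units; beyond the scatter). The estimate for compound 4 in this assay is 9000 nM, expected to fall between 3500 nM and 23000 nM.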

Compound 4, half-maximal effective concentration: 13600 nM
Beside the measured number, compound 4's estimate is 1.5-fold (0.18 log units) below it; measured number inside the range.
By their numbers in this assay, from the lowest: compound 1; then compounds 3, 4 and 2 (each within the scatter of the next).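

In this assay, the exchange of pyrimidin-5-yl for 3-chlorophenyl on this aromatic carbon, a 1.6-fold lower number from compound 2 to compound 4 (0.21 log units; within the scatter), stays within the scatter, so compound 4 joins compound 3 in not separating from compound 2. The new result also shows that moving the chlorine around the phenyl ring leaves no readable difference here, with 2-chlorophenyl giving way to 3-chlorophenyl in a 1.0-fold higher number from compound 3 to compound 4 (0.02 log units; within the scatter). Compound 1, with 2-methylphenyl, remains apart from all three others, including a 2.5-fold higher number from compound 1 to compound 4 (0.39 log units; beyond the scatter), which lies beyond the scatter.

No available evidence bears on the reason for these numbers. As far as these compounds go, it remains open whether 3-methylphenyl would read like compound 1 or like compound 4, and how a phenyl ring carrying an amine or a methoxy group would read at this place.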